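Swapping cyano for nitro in a small series

A few compounds are considered here, and "the series" means these few. Any claim that something is new, unique, unknown or untested is made for them only; others in the source may bear on it.

Compound 1 `COc1ccc(C(N)=O)cc1/C=C/c1ccc(Cl)cc1`: 87 nM
Compound 2 `COc1ccc(C(N)=O)cc1/C=C/c1ccc(C)cc1`: 1600 nM
Compound 3 `COc1ccc(C(N)=O)cc1/C=C/c1ccc(C#N)cc1`: 3100 nM

In a functional assay on HUVEC cells (Homo sapiens) for inhibition, with a stated time of 4 days (on this read-out higher numbers stand for weaker inhibition and lower numbers for stronger inhibition), compound 3 gives 3100 nM and stands at the weak end of this small set, level with compound 2 . Their gap, a 1.9-fold higher number from compound 2 to compound 3 (0.29 log units; within the scatter), is no real difference. Compound 1 stands well apart, with a 36-fold higher number from compound 1 to compound 3 (1.55 log units; beyond the scatter) as a large step.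

Compound 4 `COc1ccc(C(N)=O)cc1/C=C/c1ccc([N+](=O)[O-])cc1` differs from compound 3 in one place: nitro in place of cyano on an aromatic carbon, with nitro in place of cyano on an aromatic carbon, para to a large group. Among the measured compounds shown here, no measured compound carries nitro, so only indirect guides exist. Two large steps, an 18-fold higher number from compound 1 to compound 2 (1.26 log units; beyond the scatter) and a 36-fold higher number from compound 1 to compound 3 (1.55 log units; beyond the scatter), both leave chloro, and this swap does not. The closest guide is therefore the step between methyl and cyano, which stayed within the scatter. The expected result is a 1.2-fold lower number from compound 3 to compound 4 (0.09 log units; within the scatter), with no clear direction and no change beyond the scatter. Three compounds make a thin basis, so the range is kept wide. Compound 4 is estimated at 2500 nM, within an expected range of 600 nM to 9000 nM.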

Compound 4, half-maximal inhibitory concentration: 4700 nM
For compound 4 the middle estimate is 1.9-fold (0.27 log units) below the measured one; the range from low to high includes it.
By their numbers in this assay, from the lowest: compound 1; then compounds 2, 3 and 4 (each within the scatter of the next, the first and the last beyond it).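

In this assay, putting nitro in place of cyano on this aromatic carbon, para to a large group, gives a 1.5-fold higher number from compound 3 to compound 4 (0.18 log units; within the scatter), so these two groups cannot be told apart here. Nitro does separate from methyl, with a 2.9-fold higher number from compound 2 to compound 4 (0.47 log units; beyond the scatter), even though cyano and methyl could not be separated from each other, so compounds 2, 3 and 4 form a loose cluster rather than clean levels. Chloro remains the one group that stands apart, with a 54-fold higher number from compound 1 to compound 4 (1.73 log units; beyond the scatter), and among the four groups shown only chloro gives a low number at this position.

Nothing available gives a reason for these steps. As far as these compounds go, whether the low number belongs to chloro alone stays open, and fluoro, bromo or an amine at this position would help to settle it.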